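Methyl on the 4-hydroxyphenyl oxygen of compound 2

The source may hold more compounds than are shown below. What is called first, only, known or untested is meant among the compounds shown, and "the series" means these compounds.

In a functional assay on L5178Y cells (Mus musculus) for inhibition, read by MTT assay, with a stated time of 24 h (on this read-out lower numbers stand for stronger inhibition and higher numbers for weaker inhibition), compound 1 `COc1cc(O)c2c(c1)O[C@H](c1ccc(O)cc1)C/C2=N\NC(=O)c1ccco1` gives >= 11300 nM, which is a limit. Compound 2 `COc1cc(O)c2c(c1)O[C@H](c1ccc(O)cc1)C/C2=N\NC(=O)Cc1c[nH]c2ccccc12` gives >= 11300 nM, also a limit. The series therefore stands at the limit of >= 11300 nM in this assay, at which 2 of the 2 values shown sit.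

Compound 3 `COc1ccc([C@@H]2C/C(=N\NC(=O)Cc3c[nH]c4ccccc34)c3c(O)cc(OC)cc3O2)cc1` differs from compound 2 by methyl in place of hydrogen on an oxygen on an aromatic ring, turning 4-hydroxyphenyl to 4-methoxyphenyl. Within the data shown here, the one measured step, a step that the two limits leave unreadable from compound 1 to compound 2, concerns a different place and has no readable size, so it offers no guide to this change. The expected step in this assay is a step that the limit leaves unreadable from compound 2 to compound 3, estimated as none beyond the scatter, with no direction favoured. Compound 3 is estimated at 13000 nM, within 6000 nM to 30000 nM.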

Compound 3, half-maximal inhibitory concentration: 8600 nM
The estimate for compound 3 lay 1.5-fold (0.18 log units) above the measured number; the measured number falls inside the stated range.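

Replacing 4-hydroxyphenyl with 4-methoxyphenyl gives, in this assay, an at least 1.3-fold lower number from compound 2 to compound 3 (0.11 log units; that floor lies within the scatter). Among these compounds, because compound 2 is only a limit, the true size of this step stays unknown, and compound 3 is the only compound with a value that is a number and not a limit: the limit of >= 11300 nM in this assay, at which 2 of the 3 values shown sit A free hydroxy at this place is thus not needed for a measurable value.

Open, as far as these compounds go, is how an ethoxy or an amine at this place would read, and whether methyl on the same oxygen of compound 1, with its furan-2-yl, would also give a number.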